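The source may report more compounds than this note shows. Statements on the series, on what has been measured and on what is new or still open speak of the compounds shown alone.

Compound 1 `CC(c1ccc(-c2ccccc2)c(F)c1)c1nnc2n1N=C(c1ccc(Cl)cc1Cl)CS2` gives 6900 nM in a functional assay on HCT-116 cells (Homo sapiens) for inhibition, read by sulforhodamine B assay, with a stated time of 72 h; a higher number here means a weaker inhibitor, a lower number a stronger inhibitor. Compound 3 `CC(c1ccc(-c2ccccc2)c(F)c1)c1nnc2n1N=C(c1ccc(Br)cc1)CS2` differs from it by 4-bromophenyl in place of 2,4-dichlorophenyl on a carbon with a double bond to nitrogen; in this assay compound 3 gives 7100 nM, and the step is a 1.0-fold higher number from compound 1 to compound 3 (0.01 log units; within the scatter). Compound 2 `CC(C)Cc1ccc(C(C)c2nnc3n2N=C(c2ccc(Cl)cc2Cl)CS3)cc1` carries a different core; how its core differs from that of compound 1 is not broken down here. In this assay compound 2 gives 11100 nM, and the values of compounds 1 and 3 lie within the scatter of it. Compound 4 `CC(C)Cc1ccc(C(C)c2nnc3n2N=C(c2ccc(Br)cc2)CS3)cc1` is not yet measured; it differs from compound 2 by 4-bromophenyl in place of 2,4-dichlorophenyl on a carbon with a double bond to nitrogen, the same kind of change as that made from compound 1 to compound 3, described in the same words for its place. Since the earlier step of a 1.0-fold higher number from compound 1 to compound 3 (0.01 log units; within the scatter) lay within the scatter, compound 4 is expected to sit close to compound 2, an expected step of a 1.0-fold lower number from compound 2 to compound 4 (0.00 log units; within the scatter). The estimate for compound 4 is 11000 nM, between 6000 nM and 20000 nM.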

Compound 4, half-maximal inhibitory concentration: 7100 nM
Compound 4: the middle estimate sits 1.5-fold (0.19 log units) above what was measured; the range from low to high includes it.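

In this assay, 4-bromophenyl in place of 2,4-dichlorophenyl gives a 1.6-fold lower number from compound 2 to compound 4 (0.19 log units; within the scatter), so on this second core the step also stays within the scatter. The two steps do not differ beyond what two such steps allow: the same change on two cores in this assay, a 1.0-fold higher number (0.01 log units; within the scatter) from compound 1 to compound 3 and a 1.6-fold lower number (0.19 log units; within the scatter) from compound 2 to compound 4, 1.6-fold (0.21 log units) apart, within the scatter of two such steps. This supports carrying the change between these two cores with little expected shift in the number, but it does not show the same for any other core, and it gives no ranking of the two groups.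

Going by these compounds, it remains open whether a group carrying an amine or a carboxylic acid, in place of these two groups on a carbon with a double bond to nitrogen, would give a step beyond the scatter. On these data alone, whether the step holds on a third core is also open.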